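The source may report more compounds than this note shows. Statements on the series, on what has been measured and on what is new or still open speak of the compounds shown alone.

Measured so far:
Compound 1, `Cc1ccc(S(=O)(=O)NC(=O)Nc2ccccc2C(=O)/C=C/c2ccc(N(C)C)cc2)cc1`, gives 38.1 ug/mL in an ADME assay on the whole organism for cytotoxicity, with Artemia salina as the target, with a stated time of 24 h; a higher number here means that more compound is needed for the effect, a lower number that less compound is needed.
Compound 2, `COc1ccc(/C=C/C(=O)c2ccccc2NC(=O)NS(=O)(=O)c2ccc(C)cc2)cc1`, gives 28.1 ug/mL.
Compound 3, `Cc1ccc(S(=O)(=O)NC(=O)Nc2ccccc2C(=O)/C=C/c2ccccc2[N+](=O)[O-])cc1`, gives 40.1 ug/mL.

Compound 2 holds the lowest of the three numbers, but neither of the other two lies beyond the scatter of it. Compound 4, `C=CCOc1ccc(/C=C/C(=O)c2ccccc2NC(=O)NS(=O)(=O)c2ccc(C)cc2)cc1`, differs from compound 2 in one place: vinyl in place of hydrogen on a saturated chain carbon bound to an oxygen on an aromatic ring. Within the data shown here, no measured step changes this same position. The steps that do exist all alter the aryl group on the double-bonded chain carbon: a 1.4-fold lower number from compound 1 to compound 2 (0.13 log units; within the scatter), a 1.4-fold higher number from compound 2 to compound 3 (0.15 log units; within the scatter) and a 1.1-fold higher number from compound 1 to compound 3 (0.02 log units; within the scatter), each within the scatter. Since none of them moves the number beyond the scatter, a similarly small step is expected here, a 1.1-fold higher number from compound 2 to compound 4 (0.03 log units; within the scatter), with no direction favored. Compound 4 is therefore estimated at 30 ug/mL, within 15 ug/mL to 60 ug/mL.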

Compound 4, concentration for half-maximal effect: 6.11 ug/mL
Compound 4: middle estimate off by 4.9-fold (0.69 log units), on the high side; the whole stated range lies above it.
By their numbers in this assay, from the lowest: compound 4; then compounds 2, 1 and 3 (each within the scatter of the next).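

In this assay, going from methoxy to allyloxy on the aromatic ring brings a 4.6-fold lower number from compound 2 to compound 4 (0.66 log units; beyond the scatter) and so moves the number beyond the scatter, which no exchange of the aryl group among compounds 1, 2 and 3 had done. Compound 4 also stands apart from the other two, with a 6.6-fold lower number from compound 3 to compound 4 (0.82 log units; beyond the scatter) and a 6.2-fold lower number from compound 1 to compound 4 (0.79 log units; beyond the scatter) on record. Nothing at hand explains this shift.

The compounds shown leave open whether the double bond of the allyl group matters or the added chain alone does. A saturated propyl group on the same oxygen would separate the two.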